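Three macrocycles at the cytotoxicity limit, one more to come

This account rests on a few compounds, and the source may have more. Where it says the series, first, only, none or still open, it means among the compounds named here.

Compound 1 `CC(C)C[C@@H]1NC(=O)[C@@H](NC(=O)OC(C)(C)C)CCc2nnc(o2)CNC(=O)CC[C@@H](C=O)NC1=O` — in a functional assay on HG23 cells (Homo sapiens) for cytotoxicity (on this read-out lower numbers stand for higher toxicity in this test and higher numbers for lower toxicity in this test), compound 1 gives only the limit > 100000 nM.
Compound 2 `CC(C)(C)OC(=O)N[C@H]1CCc2nnc(o2)CCNC(=O)CC[C@@H](C=O)NC(=O)[C@H](CC2CCCCC2)NC1=O` — in this assay compound 2 gives only the limit > 100000 nM.
Compound 3 `CC(C)C[C@@H]1NC(=O)[C@@H](NC(=O)OC(C)(C)C)CCc2nnc(o2)CCCNC(=O)CC[C@@H](C=O)NC1=O` — in this assay compound 3 gives only the limit > 100000 nM.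

None of the three measured compounds yields a number in this assay; each sits at the limit of > 100000 nM in this assay, at which 3 of the 3 values shown sit. Compound 3 therefore stands nowhere in particular among them: its value is a limit, and the two values beside it are the same limit, so no order among the three can be read.

The next compound, compound 4 `CC(C)(C)OC(=O)N[C@H]1CCc2nnc(o2)CCCNC(=O)CC[C@@H](C=O)NC(=O)[C@H](CC2CCCCC2)NC1=O`, differs from compound 3 in one place: cyclohexyl in place of isopropyl on a saturated chain carbon bound to a saturated ring carbon. Among the compounds with values here, the same exchange appears between compound 1 and compound 2, and both of those compounds also reach only the limit, which gives no measured step to lean on. Nothing in the data shows any effect of this exchange on the read-out.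

The step of a number no higher from compound 3 to compound 4 (the limit leaves the size open) is expected to be none beyond the scatter, with compound 4 most likely reported again as a limit rather than a number. Compound 4 is accordingly estimated at 100000 nM, in a range from 50000 nM to 200000 nM.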

Compound 4, half-maximal cytotoxic concentration: > 100000 nM
Compound 4: a limit, no number; the forecaster's own chance of this, stated with the estimate: 85%; the middle value sits exactly at the limit.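

In this assay compound 4 gives > 100000 nM, which is a limit and not a number. No step can be read from compound 3 to compound 4, as all the values stand at one limit: the limit of > 100000 nM in this assay, at which 4 of the 4 values shown sit. The compounds shown leave open whether cyclohexyl in place of isopropyl changes this read-out at all, and at what concentration any of the four would prove toxic.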